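Series notes: benzyloxy to propargyloxy at the aryl ether

A few compounds are considered here, and "the series" means these few. Any claim that something is new, unique, unknown or untested is made for them only; others in the source may bear on it.

Of the compounds shown here, three have been measured in a functional assay on HL-60 cells (Homo sapiens) for cytotoxicity, read by MTT assay, with a stated time of 24 h; on this read-out higher numbers stand for weaker inhibition and lower numbers for stronger inhibition. Compound 1 `COc1ccccc1N1CCN(CCCCCOc2c(Br)cc(Br)cc2Oc2ccc(Br)cc2Br)CC1` gives 32.2 ug/mL. Compound 2 `C=CCOc1c(Br)cc(Br)cc1Oc1ccc(Br)cc1Br` gives 27.9 ug/mL, and compound 3 `Brc1ccc(Oc2cc(Br)cc(Br)c2OCc2ccccc2)c(Br)c1` gives 27.9 ug/mL. Compound 3 therefore stands level with compound 2 at the digits shown, the two together the lowest of the three numbers; compound 1 is the furthest from compound 3, yet that gap also sits within the scatter, so the three values are not distinguishable on this read-out.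

Among the measured compounds shown here, the only measured step between compounds differing in a single place is no change at the digits printed from compound 2 to compound 3 (within the scatter), in which phenyl replaces vinyl on a saturated chain carbon bound to an oxygen on an aromatic ring.

Compound 4 `C#CCOc1c(Br)cc(Br)cc1Oc1ccc(Br)cc1Br` is still to be measured in this assay. Relative to compound 3 it shows (ethynyl in place of phenyl on a saturated chain carbon bound to an oxygen on an aromatic ring). For the measured compounds named here, that same position was varied in the one step above, and exchanging vinyl for phenyl there left the number unchanged within the scatter; the broader change in compound 1 likewise stayed within the scatter. On this basis the expected step is a 1.0-fold higher number from compound 3 to compound 4 (0.00 log units; within the scatter), meaning no movement beyond the scatter in either direction. For compound 4 the expected result in this assay is estimated at 28 ug/mL, with a range from 15 ug/mL to 55 ug/mL.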

Compound 4, half-maximal inhibitory concentration: 29.7 ug/mL
Compound 4: the middle estimate sits 1.1-fold (0.03 log units) below what was measured, and the stated range covers the measured number.
By their numbers in this assay, from the lowest: compounds 2, 3, 4 and 1 (each within the scatter of the next).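

In this assay, the place on a saturated chain carbon bound to an oxygen on an aromatic ring now carries a third group, and exchanging phenyl for ethynyl gives a 1.1-fold higher number from compound 3 to compound 4 (0.03 log units; within the scatter) while exchanging vinyl for ethynyl gives a 1.1-fold higher number from compound 2 to compound 4 (0.03 log units; within the scatter) on the same read-out. Where the earlier step compared only vinyl with phenyl, the series now shows that ethynyl also cannot be told apart from either group here, even though this change removes a six-membered aromatic ring of carbon only, goes from 6 heavy atoms to 2 and brings in a triple bond. Nothing available explains why the number stays within the scatter across these three groups.

From the compounds shown here alone, whether this tolerance extends to a group carrying a carboxylic acid or a primary amide at the same place remains open, since phenyl, vinyl and ethynyl are all plain carbon groups with no hydrogen-bond donors or acceptors among those counted. Also open, going by these compounds, is whether a chlorine in place of a bromine on the shared core would move the number beyond the scatter.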